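Adding a tert-Butyl Group to Compound 3

A few compounds are considered here, and "the series" means these few. Any claim that something is new, unique, unknown or untested is made for them only; others in the source may bear on it.

Toxicity to cultured cells is a routine early check on new compounds, and here it is read in an ADME assay on J774.A1 cells (Mus musculus) for cytotoxicity, read by MTT assay, with a stated time of 48 h; on this read-out lower numbers stand for higher toxicity in this test and higher numbers for lower toxicity in this test. Compound 1 `O=C(NCc1ccc(F)cc1)c1c([N+](=O)[O-])noc1-c1ccc([N+](=O)[O-])cc1` has "not determined" (no result reported) as its entry and compound 2 `COc1cccc(CNC(=O)c2c([N+](=O)[O-])noc2-c2ccc([N+](=O)[O-])cc2)c1` has "not determined" (no result reported) as its entry, so neither offers a number for comparison. Among the measured compounds shown here, compound 3 `COC(=O)c1c(NCc2ccccc2)noc1-c1ccc([N+](=O)[O-])cc1` gives 85400 nM as the only number available, so it cannot be ranked against anything. Compound 4 `COC(=O)c1c(NCc2ccc(C(C)(C)C)cc2)noc1-c1ccc([N+](=O)[O-])cc1` is still unmeasured and differs from compound 3 by tert-butyl in place of hydrogen on an aromatic carbon. For the measured compounds named here, no measured pair shows what such a change does in this assay so any forecast is loose. Starting from compound 3 at 85400 nM as the sole anchor, a small step towards lower numbers is expected, possibly no larger than the usual scatter. The estimate amounts to a 1.6-fold lower number from compound 3 to compound 4 (0.19 log units; within the scatter) as an expected move. Compound 4 is expected at 55000 nM with 20000 nM to 120000 nM as the estimated range.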

Compound 4, half-maximal cytotoxic concentration: 81400 nM
Compound 4: the middle estimate sits 1.5-fold (0.17 log units) below what was measured, and the stated range covers the measured number.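

In this assay, the step is a 1.0-fold lower number from compound 3 to compound 4 (0.02 log units; within the scatter), so the two compounds cannot be told apart in this test. Among the compounds shown here, this is the first measured pair in the set, and it gives a first reading for this position, on an aromatic carbon of the six-membered ring and para to a large group: tert-butyl in place of hydrogen there leaves the cell toxicity reading indistinguishable from that of the parent compound. No measurement shown here offers an explanation for this result.

This single pair cannot say whether the same would hold for an amine, a carboxylic acid or a longer chain such as n-hexyl at this position. It also leaves open whether tert-butyl elsewhere on the same ring would give a similar reading.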